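Chloropropyl amide to acrylamide on the shared core

The source may report more compounds than this note shows. Statements on the series, on what has been measured and on what is new or still open speak of the compounds shown alone.

Compound 3 `CCCCC(OC)c1cccc(NC(=O)CCCCl)c1` is the starting point of this step. In a functional assay on MCF7 cells (Homo sapiens) for antiproliferative activity, with a stated time of 48 h (a higher number here means a weaker inhibitor, a lower number a stronger inhibitor), compound 3 reaches only > 100000 nM, which is a limit of the assay and not a number. Its two measured relatives share the core and differ at the carbonyl carbon. Compound 1 `CCCCC(OC)c1cccc(NC(=O)NCCCCl)c1` gives 50000 nM in this assay. Compound 2 `CCCCC(OC)c1cccc(NC(=O)NC(=O)CC)c1` gives only > 100000 nM in this assay, again a limit rather than a number. Among the compounds with values here, the step of an at least 2.0-fold higher number from compound 1 to compound 3 (0.30 log units; that floor lies within the scatter) and the step of an at least 2.0-fold higher number from compound 1 to compound 2 (0.30 log units; that floor lies within the scatter) both run from the one measured number up to a limit, and the step that the two limits leave unreadable from compound 2 to compound 3 cannot be read at all because of the limit of > 100000 nM in this assay, at which 2 of the 3 values shown sit.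

Compound 4 `C=CC(=O)Nc1cccc(C(CCCC)OC)c1` differs from compound 3 by vinyl in place of 3-chloropropyl on a carbonyl carbon. Within the data shown here, none of the measured steps touches a vinyl group; the only change seen on the same carbonyl carbon, from compound 1 to compound 3, moved the number up to a limit. Among the measured compounds shown here, with compound 3 itself standing at that limit, no measured step in this assay fixes a direction for the change to compound 4. Compound 4 is therefore estimated at 80000 nM, with a range from 15000 nM to 300000 nM. The step of an at least 1.2-fold lower number from compound 3 to compound 4 (0.09 log units; that floor lies within the scatter) is expected to be at most a modest one, and it may well remain hidden by a second limit.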

Compound 4, half-maximal inhibitory concentration: > 100000 nM
Compound 4 gave a limit, no number (the forecaster's own chance of this, stated with the estimate: 50%); middle value at least 1.2-fold (0.09 log units) from the limit.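

Exchanging 3-chloropropyl for vinyl on this carbonyl carbon, a change that removes the chlorine and shortens the group to 2 heavy atoms while adding a double bond, still yields no number in this assay, so a second group on this carbonyl carbon now ends at a limit rather than a number. Within the data shown here, the only step that can be read is an at least 2.0-fold higher number from compound 1 to compound 4 (0.30 log units; that floor lies within the scatter), and it repeats what compound 2 and compound 3 already showed: among the four compounds, only compound 1, with (3-chloropropyl)amino on the carbonyl carbon, gives a number, although even that step's floor stays within the usual scatter. The steps from compound 3 and from compound 2 to compound 4 cannot be read because both ends of each are limits, not numbers: the limit of > 100000 nM in this assay, at which 3 of the 4 values shown sit.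

From the compounds shown here alone, how far compound 2, compound 3 and compound 4 actually lie from one another remains open, and so does any ranking of vinyl against 3-chloropropyl on this carbonyl carbon. Among these compounds, also open is how this assay would read with a longer chain or an amine on the nitrogen of the (3-chloropropyl)amino group of compound 1, the one compound here with a number.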